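This account rests on a few compounds, and the source may have more. Where it says the series, first, only, none or still open, it means among the compounds named here.

Measured in an ADME assay on microsomes from liver (Homo sapiens) for metabolic stability, read by LC-MS, using NADPH, with stated times of 5 min and 30 min, tested at 1 uM; on this read-out lower numbers stand for slow clearance and higher numbers for fast clearance:
- compound 1 `Cn1cc(-c2cnc(NCc3c(F)ccc4c3CCO4)c3cn[nH]c(=O)c23)cn1` gives 21 mL.min-1.g-1
- compound 2 `Fc1ccc2c(c1CNc1ncc(Oc3ccccc3)c3nncn13)CCO2` gives 18 mL.min-1.g-1
- compound 3 `CN(C)Cc1ccc(C(=O)Nc2cnc(NCc3c(F)ccc4c3CCO4)n3cnnc23)cc1` gives 13 mL.min-1.g-1

The three measured compounds sit within the usual scatter of one another, so none of them can be separated from the others on these numbers. Compound 1 gives 21 mL.min-1.g-1 and thus stands level with compound 2 and compound 3 in this assay.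

Compound 4 `Cc1ncc(-c2cnc(NCc3c(F)ccc4c3CCO4)c3cn[nH]c(=O)c23)n1C` keeps the core of compound 1 and carries 1,2-dimethyl-1H-imidazol-5-yl in place of 1-methyl-1H-pyrazol-4-yl on an aromatic carbon. Among the measured compounds shown here, no two measured compounds differ in one place only, so the data show no direct precedent for this exchange. For the measured compounds named here, the only guide is the narrow spread of the measured values, with compound 2 at 18 mL.min-1.g-1 and compound 3 at 13 mL.min-1.g-1, although both of these differ from compound 1 in more than one place. On that basis, no step beyond the scatter is expected in this assay, in either direction. The estimated step is small a 1.1-fold lower number from compound 1 to compound 4 (0.02 log units; within the scatter). Compound 4 is expected at 20 mL.min-1.g-1, with an estimated range from 10 mL.min-1.g-1 to 40 mL.min-1.g-1.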

Compound 4, intrinsic clearance in microsomes: 10 mL.min-1.g-1
Estimate against measurement, compound 4: 2.0-fold (0.30 log units) above, and the stated range covers the measured number.
By their numbers in this assay, from the lowest: compounds 4, 3, 2 and 1 (each within the scatter of the next, the first and the last beyond it).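

In this assay, among the compounds shown here, the exchange of 1-methyl-1H-pyrazol-4-yl for 1,2-dimethyl-1H-imidazol-5-yl gives a 2.1-fold lower number from compound 1 to compound 4 (0.32 log units; beyond the scatter) and is the first change in one place that can be read in this set. It shows that the number responds to the group on this aromatic carbon, para to a large group, even though the two groups differ by little in what is counted: each is one five-membered aromatic ring with 2 hetero atoms, and the entering group has 7 heavy atoms against 6. The step is modest, it rests on a single pair of compounds, and nothing in the data gives a reason for it.

The compounds shown do not separate the extra methyl from the change from a pyrazole to an imidazole, so 1-methyl-1H-imidazol-5-yl or 1,3-dimethyl-1H-pyrazol-4-yl on the same carbon would be needed to tell these two apart. Also open, on these data alone, is how far the number would move with a quite different group at this place, such as morpholine or a carboxylic acid, and whether the same exchange would give a similar step on another core.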